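A few compounds are considered here, and "the series" means these few. Any claim that something is new, unique, unknown or untested is made for them only; others in the source may bear on it.

Going by the values given here, in a functional assay on KG-1 cells (Homo sapiens) for cytotoxicity, read by luminescence and CellTiter-Glo, with a stated time of 3 days (a higher number here means a weaker inhibitor, a lower number a stronger inhibitor), compound 1 (`O=C(Nc1ccc(OC(F)(F)F)cc1)c1cc(F)ccc1O`) gives 780 nM as the higher of the two numbers so far, and compound 2 (`O=C(Nc1ccc(OC(F)(F)F)c(Cl)c1)c1cc(F)ccc1O`) gives 370 nM as the lower. Compound 3 (`O=C(Nc1ccc([N+](=O)[O-])cc1)c1cc(F)ccc1O`) has nitro in place of trifluoromethoxy on an aromatic carbon, para to a large group (nitro in place of trifluoromethoxy on an aromatic carbon). Among the compounds with values here, the one measured step (a 2.1-fold lower number from compound 1 to compound 2 (0.32 log units; beyond the scatter)) is chloro in place of hydrogen, a different change, so it offers only a rough size and no direction. A modest step either way is possible, and the expected step is small (a 1.1-fold lower number from compound 1 to compound 3 (0.05 log units; within the scatter)). Compound 3 is expected to give 700 nM (estimated range 220 nM to 2300 nM).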

Compound 3, half-maximal inhibitory concentration: 1100 nM
For compound 3 the middle estimate is 1.6-fold (0.20 log units) below the measured one, within the range that was stated.
By their numbers in this assay, from the lowest: compound 2; then compounds 1 and 3 (each within the scatter of the next).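

In this assay, putting nitro in place of trifluoromethoxy on this aromatic carbon, para to a large group, gives a 1.4-fold higher number from compound 1 to compound 3 (0.15 log units; within the scatter) and so stays within the scatter. Two groups that differ in their atoms and in heavy-atom count can therefore stand here with no readable change in the cell result. Nothing measured here explains this. On these data alone, whether an amine, a carboxylic acid or a longer chain at this place would also leave the number within the scatter remains open. As far as these compounds go, whether adding chloro, as in compound 2, would lower the number for compound 3 also remains open.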